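Chain length and cytotoxicity in a three-compound series

This account rests on a few compounds, and the source may have more. Where it says the series, first, only, none or still open, it means among the compounds named here.

Compound 1 `CCCCCCCCCCCCCCCCCCCCCCCCc1cn([C@@H](CO)[C@H](O)[C@H](O)CCCCCCCCCCCCCC)nn1` and compound 2 `CCCCCCCCCCCCCC[C@@H](O)[C@@H](O)[C@H](CO)n1cc(CCCC)nn1` share a core and differ in the length of one saturated chain, which is longer in compound 1. In a functional assay on K562 cells (Homo sapiens) for cytotoxicity, read by MTT assay (a higher number here means that more compound is needed for the effect, a lower number that less compound is needed), compound 1 reads > 50000 nM, which is a limit of the assay and not a number. Among the compounds with values here, compound 2 gives 14500 nM, the only true number so far, so it has no measured neighbour to be ranked against.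

Compound 3 `CCCCCCCCCCCCCC[C@@H](O)[C@@H](O)[C@H](CO)n1cc(CCCCCCCCCCCCC)nn1` carries the same core. Its difference from compound 2 is nonyl in place of hydrogen on a saturated chain carbon, four bonds along the chain from an aromatic carbon. This gives a chain length that falls between those of the other two compounds.

Within the data shown here, no measured step yet shows what such a change does in this assay. A moderate move toward a higher number is expected, with the limit within reach. The expected step is a 1.9-fold higher number from compound 2 to compound 3 (0.29 log units; within the scatter). For compound 3 the estimated value is 28000 nM, with an expected range of 13000 nM to 50000 nM.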

Compound 3, half-maximal effective concentration: > 50000 nM
Compound 3: no number, only a limit (the forecaster's own chance of this, stated with the estimate: 40%); at least 1.7-fold (0.25 log units) between middle value and limit.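

In this assay, within the data shown here, nonyl in place of hydrogen on a saturated chain carbon, four bonds along the chain from an aromatic carbon, gives an at least 3.4-fold higher number from compound 2 to compound 3 (0.53 log units; beyond the scatter), the first readable step and the first sign that lengthening this chain moves the number upward, by a margin beyond the usual scatter. Compound 1 and compound 3 are both recorded only as limits of the assay and not as numbers, so the step between them cannot be read and the longer chains cannot be ranked against each other. Compound 2 is therefore the only compound in the series with a true number, and the long-chain end offers no further resolution: the limit of > 50000 nM in this assay, at which 2 of the 3 values shown sit.

Still open, going by these compounds, is how an added chain shorter than nonyl would read in this assay, and so at what length the number reaches the limit. Also open, on these data alone, is whether a chain carrying an amine or a carboxylic acid at this position would keep the reading within the measurable range, or whether a chain shorter than that of compound 2 would give a lower number.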